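Adding a second chloro to the core of compound 1

The source may report more compounds than this note shows. Statements on the series, on what has been measured and on what is new or still open speak of the compounds shown alone.

Measured compounds:
- compound 1 `ClCc1ccccc1Cn1cnc2ncnc(Cl)c21`: 2340 nM
- compound 2 `ClCc1cccc(Cn2cnc3nc(Cl)nc(Cl)c32)c1`: 160 nM

In a functional assay on SF-539 cells (Homo sapiens) for cytotoxicity, read by sulforhodamine B assay, with a stated time of 48 h (a higher number here means a weaker inhibitor of growth, a lower number a stronger inhibitor of growth), compound 1 gives 2340 nM, the highest of the two numbers, while compound 2 gives 160 nM, a lower number that lies beyond the scatter. Compound 2 differs from compound 1 in more than one place, so the two values alone cannot be split into separate effects. Compound 3 `ClCc1ccccc1Cn1cnc2nc(Cl)nc(Cl)c21` changes only one place: chloro in place of hydrogen on an aromatic carbon. Going by the values given here, since no single-change step is known, the direction is uncertain, but the lower number of compound 2 suggests a moderate fall. Compound 3 is expected at 600 nM, between 150 nM and 2400 nM, a step of a 3.9-fold lower number from compound 1 to compound 3 (0.59 log units; beyond the scatter) that is estimated.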

Compound 3, concentration for 50% growth inhibition: 2130 nM
Estimate against measurement, compound 3: 3.6-fold (0.55 log units) below; measured number inside the range.
By their numbers in this assay, from the lowest: compound 2; then compounds 3 and 1 (each within the scatter of the next).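

In this assay, chloro in place of hydrogen on this aromatic carbon, between two ring nitrogen atoms, gives a 1.1-fold lower number from compound 1 to compound 3 (0.04 log units; within the scatter) and so no readable effect here. Compound 3 carries the same two chloro groups on the core as compound 2, yet compound 3 gives 2130 nM while compound 2 gives 160 nM in the same test, so the second chloro alone does not account for that lower number. Nothing measured here offers an explanation for this result. Going by these compounds, whether an amine or a methoxy group on this carbon would read differently stays open. So does what this chloro does when the chloromethyl group sits where compound 2 has it.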